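Sulfonyl group change from compound 3 to compound 4

The compounds below may be only part of what the source reports. "The series", "measured", "known", "first", "only" and "open" are said of these compounds alone.

Measured in a functional assay on A549 cells (Homo sapiens) for cytotoxicity, read by MTT assay, with a stated time of 72 h; a higher number here means a weaker inhibitor, a lower number a stronger inhibitor
compound 1 `COc1ncc(-c2ccc3nc(NC(=O)NCCN4CCCC4)nn3c2)cc1NS(=O)(=O)c1ccc(F)cc1`: 960 nM
compound 2 `COc1ncc(-c2ccc3nc(NC(=O)NC4CC4)nn3c2)cc1NS(=O)(=O)c1ccc(F)cc1`: 210 nM
compound 3 `CCN(CC)CCNC(=O)Nc1nc2ccc(-c3cnc(OC)c(NS(=O)(=O)c4ccc(F)cc4F)c3)cn2n1`: 980 nM

In this assay compound 3 at 980 nM lies within the scatter of compound 1, and both lie above compound 2. Compound 4 `CCN(CC)CCNC(=O)Nc1nc2ccc(-c3cnc(OC)c(NS(=O)(=O)c4ccc(C)cc4)c3)cn2n1` has 4-methylphenyl in place of 2,4-difluorophenyl on a sulfonyl sulfur. Within the data shown here, the one measured step, a 4.6-fold lower number from compound 1 to compound 2 (0.66 log units; beyond the scatter), is beyond the scatter but concerns the group on an amide-type nitrogen, so it does not bear on this change. Among the measured compounds shown here, no measured pair isolates the group on the sulfonyl sulfur, so compound 3 at 980 nM serves as the anchor. The expected step is a 1.1-fold lower number from compound 3 to compound 4 (0.04 log units; within the scatter) and so none beyond the scatter. For compound 4 the estimate is 900 nM, with an expected range of 350 nM to 2400 nM.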

Compound 4, half-maximal inhibitory concentration: 730 nM
The estimate for compound 4 lay 1.2-fold (0.09 log units) above the measured number; the range from low to high includes it.
By their numbers in this assay, from the lowest: compound 2; then compounds 4, 1 and 3 (each within the scatter of the next).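

In this assay the group on the sulfonyl sulfur now has its first measured pair: 4-methylphenyl in place of 2,4-difluorophenyl gives a 1.3-fold lower number from compound 3 to compound 4 (0.13 log units; within the scatter). With the rest of compound 3 held, this assay therefore does not separate these two aryl groups. No measurement at hand offers an account of this result.

From the compounds shown here alone, whether the same holds with cyclopropyl on the amide-type nitrogen remains open. Also open, going by these compounds, is how a methyl group directly on the sulfonyl sulfur, or an amine on the phenyl ring, would read here.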